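Fluoro to Methoxy: What Compound 4 Might Show

The source may report more compounds than this note shows. Statements on the series, on what has been measured and on what is new or still open speak of the compounds shown alone.

Of the compounds shown here, three have been measured in a functional assay, read by spectrophotometry, with a stated time of 15 min, tested at 100 ug/mL; a lower number here means a weaker effect, a higher number a stronger effect of the compound at the concentration tested. Compound 1 `Clc1ccc(-c2csc(N/N=C/c3cccs3)n2)cc1` gives 87.1%, compound 2 `Fc1ccc(-c2csc(N/N=C/c3ccc(Cl)cc3Cl)n2)cc1` gives 95.6%, and compound 3 `COC(=O)c1cc(-c2csc(N/N=C/c3ccc(Cl)cc3Cl)n2)ccc1OCc1ccccc1` gives 75%. Compound 2 therefore holds the highest of the three numbers, but its gap to compound 1 lies within the usual scatter of repeated measurements, so those two cannot be put in order; only compound 3 is clearly lower than compound 2.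

Compound 4 `COc1ccc(-c2csc(N/N=C/c3ccc(Cl)cc3Cl)n2)cc1` has not yet been measured. It differs from compound 2 in a single place: methoxy in place of fluoro on an aromatic carbon. Among the measured compounds shown here, no measured pair in this set shows this same exchange, so there is no direct guide to its effect. Because compound 2 already gives 95.6%, close to the top of the scale, little room remains for a rise, and a drop of modest size or none beyond the scatter seems the likeliest outcome. Compound 4 is expected to give 88%, within a range from 72% to 98%. The step expected from compound 2 to compound 4 is a number 7.6 percentage points lower from compound 2 to compound 4 (within the scatter).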

Compound 4, a percentage reported as inhibition, at one concentration (the size of the read-out at that concentration, not a potency): 87.5%
Compound 4: the middle estimate sits 0.5 percentage points above what was measured, and the stated range covers the measured number.
By their numbers in this assay, from the lowest: compound 3; then compounds 1, 4 and 2 (each within the scatter of the next).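

Among the compounds shown here, this is the first exchange in the set that can be read directly: in this assay, going from 4-fluorophenyl to 4-methoxyphenyl gives a number 8.1 percentage points lower from compound 2 to compound 4 (within the scatter). It shows that this position, on a six-membered aromatic ring of carbon only and para to a large group, can carry methoxy, with 2 heavy atoms and a hydrogen-bond acceptor, in place of fluoro, with 1 heavy atom and no acceptor, without a difference that stands clear of the scatter. No measurement here offers an explanation for this result.

As far as these compounds go, it remains open whether an amine, a carboxylic acid or a longer chain such as butoxy would be tolerated at this position in the same way. From the compounds shown here alone, the read-out comes from a single concentration, so any difference in potency between compound 2 and compound 4 also remains unknown.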